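The source may hold more compounds than are shown below. What is called first, only, known or untested is meant among the compounds shown, and "the series" means these compounds.

Of the compounds shown here, three that share one core have been measured in an assay on isolated protein for inhibition of proto-oncogene tyrosine-protein kinase receptor Ret (Homo sapiens), read by mobility shift assay, with a stated time of 1 h, tested at 10 uM; a lower number here means less inhibition, a higher number more inhibition at the concentration tested (going by the name of the read-out). Compound 1 `CN(C)CCn1cnnc1-c1cc(Oc2ccc(NC(=O)Nc3ccc(Cl)c(C(F)(F)F)c3)cc2F)ccn1` gives 74.1% in this assay. Compound 2 `CN(C)CCn1cnnc1-c1cc(Oc2ccc(NC(=O)Nc3cccc(C(F)(F)F)c3)cc2F)ccn1` gives 77.7% in this assay. Compound 3 `CCN(CC)CCn1cnnc1-c1cc(Oc2ccc(NC(=O)Nc3ccc(Cl)c(C(F)(F)F)c3)cc2F)ccn1` gives 84.4% in this assay, which is the highest of the three numbers; its gap to compound 2 lies within the usual scatter of repeated measurements, whereas the step from compound 1 is a number 10.3 percentage points higher from compound 1 to compound 3 (beyond the scatter), a modest rise that goes beyond the scatter.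

Compound 4 `CCN(CC)CCn1cnnc1-c1cc(Oc2ccc(NC(=O)Nc3cccc(C(F)(F)F)c3)cc2F)ccn1` is the next compound. Compared with compound 3, the change is hydrogen in place of chloro on an aromatic carbon. Within the data shown here, the only measured step that bears on this change is a number 3.6 percentage points higher from compound 1 to compound 2 (within the scatter), a small rise that lies within the scatter, so the change from chloro to hydrogen has so far made no reliable difference in this assay. On that basis the step from compound 3 is expected to be small, in either direction or none at all beyond the scatter: a number 1.6 percentage points higher from compound 3 to compound 4 (within the scatter). Compound 4 is therefore estimated at 86% in this assay, with a range from 76% to 94%, which would leave it close to compound 3 and to compound 2.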

Compound 4, a percentage reported as inhibition, at one concentration (the size of the read-out at that concentration, not a potency): 72.1%
For compound 4 the middle estimate is 13.9 percentage points above the measured one; the measured number lies below the stated range.
By their numbers in this assay, from the lowest: compounds 4, 1, 2 and 3 (each within the scatter of the next, the first and the last beyond it).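

In this assay, hydrogen in place of chloro on this aromatic carbon is not a change without consequence: with the diethylamino chain in place, it gives a number 12.3 percentage points lower from compound 3 to compound 4 (beyond the scatter) and so moves the number beyond the scatter, which the dimethylamino pair had not shown. The outcome of changing 4-chloro-3-(trifluoromethyl)phenyl to 3-(trifluoromethyl)phenyl therefore depends on the amine at the other end of the molecule, and the two sites cannot be treated as independent: the same change on two cores in this assay, a number 3.6 percentage points higher (within the scatter) from compound 1 to compound 2 and a number 12.3 percentage points lower (beyond the scatter) from compound 3 to compound 4, 15.9 percentage points apart, beyond the scatter of two such steps. The same holds when the amine is the part that changes, since without the chloro the swap to diethylamino gives a number 5.6 percentage points lower from compound 2 to compound 4 (within the scatter) and the gain seen earlier appears only with the chloro present: the same change on two cores in this assay, a number 10.3 percentage points higher (beyond the scatter) from compound 1 to compound 3 and a number 5.6 percentage points lower (within the scatter) from compound 2 to compound 4, 15.9 percentage points apart, beyond the scatter of two such steps.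

This dependence rests on a single set of four compounds, each read at one concentration, so it says nothing yet about potency. From the compounds shown here alone, whether it extends to other groups on this aromatic carbon, such as fluoro, methyl or methoxy, or to a ring amine such as pyrrolidine or morpholine in place of diethylamino, remains open.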